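This account rests on a few compounds, and the source may have more. Where it says the series, first, only, none or still open, it means among the compounds named here.

Measured compounds in the series:
- compound 1, `O=C(Nc1ccc(S(=O)(=O)N2CCOCC2)cc1)C1C(C(=O)O)[C@H]2CC[C@@H]1O2`: 31300 nM
- compound 2, `CCOC(=O)Cc1csc(NC(=O)C2C(C(=O)O)[C@H]3CC[C@@H]2O3)n1`: only a limit of the assay, > 100000 nM

Two compounds have been run in a functional assay on HCT-8 cells (Homo sapiens) for cytotoxicity, read by MTT assay, with a stated time of 48 h; a lower number here means a stronger inhibitor, a higher number a weaker inhibitor. Among the compounds with values here, compound 1 gives 31300 nM, the only numeric value in the set. Compound 2 returns a limit of the assay rather than a number, > 100000 nM. That is the limit of > 100000 nM in this assay, at which 1 of the 2 values shown sits, so compound 1 stands as the sole quantified point and nothing places it above or below another measured compound. Within the data shown here, no step between two measured compounds is available, and the change to compound 2 is unrelated to the one considered here.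

Compound 3, `O=C(Nc1ccc(S(=O)(=O)NC2CC2)cc1)C1C(C(=O)O)[C@H]2CC[C@@H]1O2`, differs from compound 1 by cyclopropylamino in place of morpholin-4-yl on a sulfonyl sulfur. Among the measured compounds shown here, no measured step bears on this exchange, so the expectation rests on compound 1 alone, with the step from compound 1 to compound 3 estimated at a 1.1-fold higher number from compound 1 to compound 3 (0.05 log units; within the scatter), that is no shift beyond the scatter in either direction. Compound 3 is accordingly expected near 35000 nM, with a range of 12000 nM to 100000 nM.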

Compound 3, half-maximal inhibitory concentration: 28300 nM
Compound 3: middle estimate off by 1.2-fold (0.09 log units), on the high side, within the range that was stated.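

In this assay, the exchange on the sulfonyl sulfur now has a measured step: a 1.1-fold lower number from compound 1 to compound 3 (0.04 log units; within the scatter). Replacing morpholin-4-yl with cyclopropylamino therefore swaps a six-membered ring for a three-membered one and adds a hydrogen-bond donor without a shift beyond the scatter, so this one pair shows no sensitivity to the change at this position. No measurement shown here explains why the step is so small.

On these data alone, it remains open whether a different group on the sulfonyl sulfur, such as piperazin-1-yl or dimethylamino, would move the value beyond the scatter. Also open, as far as these compounds go, is how a methyl ester or a primary amide in place of the carboxylic acid on the shared core would read in this assay.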